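The compounds below may be only part of what the source reports. "The series", "measured", "known", "first", "only" and "open" are said of these compounds alone.

Working notes on the series, read in an ADME assay on SH-SY5Y cells (Homo sapiens) for cytotoxicity, read by sulforhodamine B assay, with a stated time of 72 h; a higher number here means a weaker inhibitor, a lower number a stronger inhibitor. Within the data shown here, compound 1 (`O=C(NCCNc1cccc2ccccc12)C1CCN(Cc2ccccc2)CC1`) gives 13600 nM, the only numeric value so far. Compound 2 (`Cc1c(NC(=O)C2CCN(Cc3ccccc3)CC2)c(=O)n(-c2ccccc2)n1C`) reads > 100000 nM, which is a limit of the assay and not a number. Compound 3 (`O=C(NCc1ccccn1)C1CCN(Cc2ccccc2)CC1`) reads > 100000 nM, which is likewise a limit and not a number. Compound 3 thus sits at the limit of > 100000 nM in this assay, at which 2 of the 3 values shown sit, so its true position is not known.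

The next compound to read is compound 4 (`O=C(NCc1ccncc1)C1CCN(Cc2ccccc2)CC1`). It has pyridin-4-yl in place of pyridin-2-yl on a saturated chain carbon bound to an amide-type nitrogen, with the same atoms joined differently: pyridin-4-yl in place of pyridin-2-yl on a saturated chain carbon bound to an amide-type nitrogen.

Among the measured compounds shown here, no measured pair isolates a change of this kind, so the expectation has no direct precedent. No step beyond the usual scatter is expected, and neither direction is favoured. The nearest measured compound is compound 3, and the expectation rests on its reading of > 100000 nM, a limit. The expected step is a number no higher from compound 3 to compound 4 (the limit leaves the size open). A report of compound 4 as a limit is also likely. The estimated value for compound 4 is 100000 nM, with an expected range of 40000 nM to 200000 nM.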

Compound 4, half-maximal inhibitory concentration: 3370 nM
Compound 4: middle estimate off by 30-fold (1.47 log units), on the high side; measured number below the stated range.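

In this assay, pyridin-4-yl in place of pyridin-2-yl on a saturated chain carbon bound to an amide-type nitrogen gives an at least 29-fold lower number from compound 3 to compound 4 (1.47 log units; beyond the scatter). Among these compounds, this is the first pair that differs in one place, and it shows that the reading at this position can respond strongly to how the same atoms are joined, even though the counts of heavy atoms, donors and acceptors stay the same. Going by these compounds, the true size of the step remains unknown, since the reading of compound 3 is a limit and not a number: the limit of > 100000 nM in this assay, at which 2 of the 4 values shown sit.

The compounds shown leave open where pyridin-3-yl or a plain phenyl ring in the same place would fall in this assay, and whether a longer chain between the amide-type nitrogen and the pyridin-4-yl ring would keep the reading of compound 4. They also leave open whether the same exchange of pyridin-2-yl for pyridin-4-yl would give a step of similar direction on a different group at the amide, or with a group other than benzyl on the shared core.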